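The compounds below may be only part of what the source reports. "The series", "measured", "known", "first", "only" and "open" are said of these compounds alone.

Compound 3 `O=C(CSc1nnc(-c2ccncc2)o1)N/N=C/c1ccc([N+](=O)[O-])cc1` shares its core with compound 1 `O=C(CSc1nnc(-c2ccncc2)o1)N/N=C/c1ccc(F)cc1` and compound 2 `O=C(CSc1nnc(-c2ccncc2)o1)N/N=C/c1ccc(Br)cc1`, carrying a nitro group where those carry a fluoro or a bromo group. In a functional assay on HepG2 cells (Homo sapiens) for cytotoxicity, read by MTT assay, with a stated time of 48 h (on this read-out lower numbers stand for stronger inhibition and higher numbers for weaker inhibition), compound 1 gives 12300 nM, compound 2 gives 18600 nM, and compound 3 gives 17900 nM, so compound 3 stands second highest of the three numbers, though all three lie within the scatter of one another. Compound 4 `O=C(CSc1nnc(-c2ccncc2)o1)N/N=C/c1ccc(O)cc1` differs from compound 3 in one place: hydroxy in place of nitro on an aromatic carbon. Among the measured compounds shown here, the steps that bear on this change are a 1.0-fold lower number from compound 2 to compound 3 (0.02 log units; within the scatter) and a 1.5-fold higher number from compound 1 to compound 3 (0.16 log units; within the scatter), both within the scatter, so for compound 4 no step beyond the scatter is expected in this assay. Compound 4 is therefore estimated at 15000 nM, with a range from 5000 nM to 45000 nM, which means an expected step of a 1.2-fold lower number from compound 3 to compound 4 (0.08 log units; within the scatter).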

Compound 4, half-maximal inhibitory concentration: 5510 nM
The estimate for compound 4 lay 2.7-fold (0.43 log units) above the measured number, within the range that was stated.
By their numbers in this assay, from the lowest: compound 4; then compounds 1, 3 and 2 (each within the scatter of the next).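

In this assay, compound 1, compound 2 and compound 3 stayed within the scatter of one another, so this aromatic carbon had shown no response to the change of group. With hydroxy, a 3.2-fold lower number from compound 3 to compound 4 (0.51 log units; beyond the scatter) and a 3.4-fold lower number from compound 2 to compound 4 (0.53 log units; beyond the scatter) as well as a 2.2-fold lower number from compound 1 to compound 4 (0.35 log units; beyond the scatter) all lie beyond the scatter, which makes compound 4 the most potent of the four, by modest steps. Nothing at hand explains this difference. From the compounds shown here alone, whether an amine or a methoxy group at this place would follow compound 4 or the other three remains open.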